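Removing the aryl ester side chain of compound 2

A few compounds are considered here, and "the series" means these few. Any claim that something is new, unique, unknown or untested is made for them only; others in the source may bear on it.

In a functional assay on DU-145 cells (Homo sapiens) for cytotoxicity, read by trypan blue exclusion, with a stated time of 96 h (a lower number here means a stronger inhibitor, a higher number a weaker inhibitor), compound 1 `COC(=O)CNc1cc(CS(=O)(=O)/C=C/c2c(OC)cc(OC)cc2OC)ccc1OC` gives 100 nM, compound 2 `COC(=O)C(Nc1cc(CS(=O)(=O)/C=C/c2c(OC)cc(OC)cc2OC)ccc1OC)c1ccc(F)cc1` gives 300 nM and compound 3 `COC(=O)C(Nc1cc(CS(=O)(=O)/C=C/c2c(OC)cc(OC)cc2OC)ccc1OC)c1ccc(OC)cc1` gives 250 nM. Compound 2 stands at the upper end of these numbers, but it cannot be told apart from its aryl-bearing partner: a 1.2-fold lower number from compound 2 to compound 3 (0.08 log units; within the scatter). The clear gap is to the compound without an aryl group: a 3.0-fold higher number from compound 1 to compound 2 (0.48 log units; beyond the scatter). The other aryl group gives a similar gap: a 2.5-fold higher number from compound 1 to compound 3 (0.40 log units; beyond the scatter).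

Compound 4 `COc1cc(OC)c(/C=C/S(=O)(=O)Cc2ccc(OC)c(NC(C)(C)C(=O)O)c2)c(OC)c1` is unmeasured and differs from compound 2 as follows: 1-carboxy-1-methylethyl in place of (4-fluorophenyl)(methoxycarbonyl)methyl on a nitrogen on an aromatic ring. In words, 1-carboxy-1-methylethyl stands in place of (4-fluorophenyl)(methoxycarbonyl)methyl on a nitrogen on an aromatic ring. The aryl group is lost, so the modest steps above bear on the change in reverse, and some return towards the 100 nM of compound 1 is expected. Going by the values given here, no measured step covers the carboxy group or the methyl groups of the entering chain, so the expectation stays loose. The estimated change is modest and towards a lower number: a 1.9-fold lower number from compound 2 to compound 4 (0.27 log units; within the scatter). For compound 4 the expected value is 160 nM, with an estimated range of 50 nM to 600 nM.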

Compound 4, half-maximal inhibitory concentration: 150 nM
Compound 4: middle estimate off by 1.1-fold (0.03 log units), on the high side; low and high end bracket the measured number.
By their numbers in this assay, from the lowest: compounds 1, 4, 3 and 2 (each within the scatter of the next, the first and the last beyond it).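

In this assay, the swap to 1-carboxy-1-methylethyl on the nitrogen on an aromatic ring gives a result that cannot be separated from either neighbour (a 2.0-fold lower number from compound 2 to compound 4 (0.30 log units; within the scatter)) (a 1.5-fold higher number from compound 1 to compound 4 (0.18 log units; within the scatter)). Going by these compounds alone, the earlier compounds showed only that adding an aryl group to the chain of compound 1 gave steps beyond the scatter; compound 4 shows that this nitrogen also carries a chain with no ring and a free carboxy group, with the number staying within the scatter of both compound 1 and compound 2. Nothing measured in the series accounts for this result, and the reading stays at the level of the numbers.

As far as these compounds go, the aryl group and the methyl ester leave together in this change while the methyl groups and the carboxy group enter together, so the share of each part stays open, and the comparison of the carboxylic acid with its methyl ester on an otherwise identical chain would separate two of them. Also open, from the compounds shown here alone, is how a primary amide, or a longer chain ending in an amine, would read at this nitrogen.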